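Bromo in Place of Benzoyl on the Shared Core

A few compounds are considered here, and "the series" means these few. Any claim that something is new, unique, unknown or untested is made for them only; others in the source may bear on it.

Measured compounds:
compound 1: `O=C(c1ccccc1)c1ccc2c(c1)oc(=O)n2C(=O)NCCCCc1ccccc1` — 29 nM
compound 2: `O=C(NCCCCCCc1ccccc1)n1c(=O)oc2ccccc21` — 51 nM
compound 3: `Cc1cccc2c1oc(=O)n2C(=O)NCCCCc1ccccc1` — 23 nM

All three were tested in an assay on HEK293 cells for inhibition of acid ceramidase (Homo sapiens), with a stated time of 10 min; a higher number here means a weaker inhibitor, a lower number a stronger inhibitor. Compound 1 gives the second highest of the three numbers; compound 3 is nearest and compound 2 furthest, and both gaps fall within the usual scatter of this assay. The three values therefore show no real separation.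

Compound 4, `O=C(NCCCCc1ccccc1)n1c(=O)oc2cc(Br)ccc21`, has not yet been measured. It differs from compound 1 in one place: bromo in place of benzoyl on an aromatic carbon

For the measured compounds named here, no measured pair in this set shows this exact change, so the expected step can only be judged from what the values show. Compound 3 carries a small methyl on the core and gives 23 nM, which lies close to the value of compound 1, 29 nM. A bromo group is also a single small substituent. The step of a 1.2-fold lower number from compound 1 to compound 4 (0.06 log units; within the scatter) is therefore expected to be small, with no direction beyond the scatter. Compound 4 is estimated at 25 nM, with a likely range from 10 nM to 70 nM.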

Compound 4, half-maximal inhibitory concentration in the acid ceramidase assay: 31 nM
The estimate for compound 4 lay 1.2-fold (0.09 log units) below the measured number; low and high end bracket the measured number.
By their numbers in the acid ceramidase assay, from the lowest: compounds 3, 1, 4 and 2 (each within the scatter of the next, the first and the last beyond it).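

Replacing the whole benzoyl group with a single bromo atom makes no real difference in the acid ceramidase assay: a 1.1-fold higher number from compound 1 to compound 4 (0.03 log units; within the scatter). For the compounds shown here, this one-place comparison, which the earlier compounds did not offer, shows that the ring and carbonyl of benzoyl are not required at this aromatic carbon for a number in this range. In a physicochemical assay for metabolic stability, read by HPLC, in phosphate buffer, at pH 7.4, tested at 10 uM (a lower number here means that the compound disappears faster, a higher number that the compound lasts longer), compound 1 gives 1.63 h and compound 4 gives 0.4 h, so the same change does register in how long the compound lasts: the measured half-life of compound 1, 1.63 h, and of compound 4, 0.4 h, a 4.1-fold lower number (0.61 log units; beyond the scatter).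

On these data alone, whether this shorter half-life comes from the arrival of bromo or the departure of benzoyl remains open. Also open, as far as these compounds go, is how an amine or a methoxy group at this aromatic carbon would fare in the acid ceramidase assay and in the physicochemical assay.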